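The compounds below may be only part of what the source reports. "The series", "measured", "known", "first", "only" and "open" are said of these compounds alone.

Working notes on the series. In an ADME assay on HepG2 cells (Homo sapiens) for cytotoxicity, read by MTT assay, with a stated time of 72 h (on this read-out lower numbers stand for higher toxicity in this test and higher numbers for lower toxicity in this test), compound 3 `CCC(O)CC#Cc1cc(Cl)cn2c([N+](=O)[O-])c(CS(=O)(=O)c3ccccc3)nc12` stands at > 62500 nM, which is a limit and not a number. Compound 2 `O=[N+]([O-])c1c(CS(=O)(=O)c2ccccc2)nc2c(C#CCCO)cc(Cl)cn12` gives > 125000 nM, also a limit. Compound 1 `O=[N+]([O-])c1c(CS(=O)(=O)c2ccccc2)nc2c(C#Cc3cccs3)cc(Cl)cn12` gives > 3900 nM, again a limit. Among the measured compounds shown here, no compound in the set therefore has a measured value, and compound 3 can be placed only by its limit.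

Compound 4 `O=[N+]([O-])c1c(CS(=O)(=O)c2ccccc2)nc2c(C#CC3(O)CCCC3)cc(Cl)cn12` differs from compound 3 by 1-hydroxycyclopentyl in place of 2-hydroxybutyl on a triple-bonded carbon.

The closest measured comparison is a step that the two limits leave unreadable from compound 2 to compound 3, which also changes the group on the triple-bonded carbon. The steps a step that the two limits leave unreadable from compound 1 to compound 2 and a step that the two limits leave unreadable from compound 1 to compound 3 bear on the same place. For the measured compounds named here, none of the three has a readable size, so the data give no measured step to scale this change.

In this assay no step beyond the scatter is expected, and none is expected in either direction. This expectation rests on the limit of compound 3 at > 62500 nM. The expected step is an at least 1.0-fold lower number from compound 3 to compound 4 (0.01 log units; that floor lies within the scatter). For compound 4 the estimated value is 60000 nM, with an expected range from 15000 nM to 125000 nM, and a report as a limit alone is more likely than a number.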

Compound 4, half-maximal cytotoxic concentration: > 31300 nM
Compound 4: a limit, no number; the forecaster's own chance of this, stated with the estimate: 70%; the middle value lies beyond the limit too.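

In this assay compound 4 gives a limit, as do compound 1, compound 2 and compound 3, so none of its steps from those three compounds can be read. The compounds shown leave open what number any of them would give, and whether the group on the triple-bonded carbon changes this read-out at all.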